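The compounds below may be only part of what the source reports. "The series", "measured", "known", "first", "only" and "open" are said of these compounds alone.

Measured compounds:
- compound 1, `C[C@@H]1O[C@@H](O[C@H]2COC(=O)C2)[C@H](O)[C@H](O)[C@H]1O`: 41200 nM
- compound 2, `O=C1C[C@@H](O[C@H]2O[C@H](CO)[C@@H](O)[C@H](O)[C@H]2O)CN1`: 89000 nM

Both numbers come from a functional assay on RAW264.7 cells (Mus musculus) for inhibition, read by Griess assay, with a stated time of 24 h; a lower number here means a stronger inhibitor, a higher number a weaker inhibitor. Of the two values shown, compound 2 has the higher one, so it stands as the weaker inhibitor of the pair; compound 1 gives the lower number, and the gap between them lies beyond the usual scatter of repeated measurements.

Compound 3, `O=C1C[C@@H](O[C@H]2O[C@H](CO)[C@@H](O)[C@H](O)[C@@H]2O)CN1`, has not yet been measured in this assay. It differs from compound 2 as follows: the two compounds have the same atoms and bonds and differ only in configuration as drawn: 1 of 6 stereo elements differ; a stereocentre at a saturated ring carbon is drawn R in compound 2 and S in compound 3.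

Within the data shown here, no step between measured compounds of this kind is available, so the size of the effect of changing the configuration at a single saturated ring carbon cannot be read from the data. Given that compound 2 is a weak inhibitor, compound 3 is expected to show a step of a 1.1-fold lower number from compound 2 to compound 3 (0.05 log units; within the scatter), that is, no change beyond the scatter. Compound 3 is therefore estimated at 80000 nM, in a range from 30000 nM to 250000 nM.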

Compound 3, half-maximal inhibitory concentration: 108000 nM
Beside the measured number, compound 3's estimate is 1.4-fold (0.13 log units) below it; low and high end bracket the measured number.
By their numbers in this assay, from the lowest: compound 1; then compounds 2 and 3 (each within the scatter of the next).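

Among these compounds, the pair gives the first reading of what a single stereocentre is worth here, something compounds 1 and 2 alone could not supply. In this assay, drawing this saturated ring carbon S rather than R gives a 1.2-fold higher number from compound 2 to compound 3 (0.08 log units; within the scatter), so the two configurations cannot be told apart in this assay. The step can be assigned to this one stereocentre alone, with no other structural difference involved: the fact that compounds 2 and 3 differ only in the configuration as drawn

The compounds shown leave open whether the same indifference would hold at the other stereocentres of the shared core, or in a compound with a lower number in this assay. They also do not tell whether an amine or a carboxylic acid on the shared core would make the configuration at this carbon matter.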